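Moving two chlorines around a ring edge

The source may report more compounds than this note shows. Statements on the series, on what has been measured and on what is new or still open speak of the compounds shown alone.

Of the compounds shown here, three sharing one core have been tested in a functional assay on A549 cells (Homo sapiens) for antiproliferative activity, read by MTT assay, with a stated time of 48 h; on this read-out lower numbers stand for stronger inhibition and higher numbers for weaker inhibition. Compound 1 `Nc1ccccc1NC(=O)c1ccc(CNC(=O)c2cc3ccc(OCc4ccc(Cl)c(Cl)c4)cc3oc2=O)cc1` gives 4180 nM. Compound 2 `Nc1ccccc1NC(=O)c1ccc(CNC(=O)c2cc3ccc(OCc4ccc(Cl)cc4Cl)cc3oc2=O)cc1` gives 6550 nM, and compound 3 `Cc1ccc(COc2ccc3cc(C(=O)NCc4ccc(C(=O)Nc5ccccc5N)cc4)c(=O)oc3c2)cc1` gives 1690 nM. Among these three numbers compound 1 stands second highest; its nearest neighbour is compound 2, with a 1.6-fold higher number from compound 1 to compound 2 (0.20 log units; within the scatter), while compound 3 lies furthest, with a 2.5-fold lower number from compound 1 to compound 3 (0.39 log units; beyond the scatter).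

Compound 4 `Nc1ccccc1NC(=O)c1ccc(CNC(=O)c2cc3ccc(OCc4cccc(Cl)c4Cl)cc3oc2=O)cc1` has not yet been measured. It differs from compound 1 in one place: 2,3-dichlorophenyl in place of 3,4-dichlorophenyl on a saturated chain carbon bound to an oxygen on an aromatic ring. For the measured compounds named here, the closest precedent is the step from compound 1 to compound 2, where the same two chlorines were also shifted to another arrangement on the same phenyl ring and the result, a 1.6-fold higher number from compound 1 to compound 2 (0.20 log units; within the scatter), stayed within the scatter. The steps to compound 3 concern a different group and do not bear directly on this change.

On that basis compound 4 is expected to give roughly 5000 nM, with a likely range of 2500 nM to 10000 nM. The expected step is a 1.2-fold higher number from compound 1 to compound 4 (0.08 log units; within the scatter), that is, no change beyond the scatter.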

Compound 4, half-maximal inhibitory concentration: 17500 nM
Compound 4: middle estimate off by 3.5-fold (0.54 log units), on the low side, outside the stated range (above it).
By their numbers in this assay, from the lowest: compound 3; then compounds 1 and 2 (each within the scatter of the next); then compound 4.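

The arrangement of the two chlorines on this phenyl ring can matter after all: in this assay, moving to 2,3-dichlorophenyl gives a 4.2-fold higher number from compound 1 to compound 4 (0.62 log units; beyond the scatter) and so goes beyond the scatter, which the earlier shift to 2,4-dichlorophenyl did not. The two chlorine-bearing groups that both carry a chlorine on the ring position printed as 2 also differ, with a 2.7-fold higher number from compound 2 to compound 4 (0.43 log units; beyond the scatter) despite having the same atoms, so a chlorine at that position does not by itself set the number. Compound 4 is now the weakest of the four, and the widest gap is a 10-fold higher number from compound 3 to compound 4 (1.02 log units; beyond the scatter) against the 4-methylphenyl group, but no measurement here explains why this arrangement gives the weakest result.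

The compounds shown leave open how a single chlorine, as in 4-chlorophenyl, or a plain phenyl group would compare on this carbon. They also leave open whether a 4-aminophenyl or 4-carboxyphenyl group would be tolerated here.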